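Aryloxypropyl piperazines: methoxy to nitro on the fused ring

The source may hold more compounds than are shown below. What is called first, only, known or untested is meant among the compounds shown, and "the series" means these compounds.

Measured so far:
compound 1, `Oc1cc2c(cc1OCCCN1CCN(c3ccccc3)CC1)CCC2`: 0%
compound 2, `COc1cc2c(cc1OCCCN1CCN(c3ccccc3)CC1)CCC2`: 65%

Both were tested in a functional assay on the whole organism for inhibition, with Mus musculus as the target, at a dose of 25 mg/kg by the oral route; a higher number here means more inhibition at the dose given (going by the name of the read-out), a lower number less inhibition. Compound 2 stands highest of the two numbers; its nearest neighbour, compound 1, lies far lower, and the gap is beyond the scatter. For the measured compounds named here, the one measured step, a number 65 percentage points higher from compound 1 to compound 2 (beyond the scatter), puts methyl in place of hydrogen on an oxygen on an aromatic ring.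

The next compound, compound 3, `O=[N+]([O-])c1cc2c(cc1OCCCN1CCN(c3ccccc3)CC1)CCC2`, changes the same place again: nitro in place of methoxy on an aromatic carbon. Going by the values given here, no measured step covers a nitro group, so the step from compound 1 to compound 2 bears on it only loosely, by showing that the group on this aromatic carbon of the fused ring moves the read-out in this assay by a large amount. The direction for nitro is not told by either measured compound.

Compound 3 is therefore expected to fall somewhere between the two measured compounds, at about 35%, with a wide range from 5% to 70%. The step of a number 30 percentage points lower from compound 2 to compound 3 (beyond the scatter) is the estimated change, downward but uncertain.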

Compound 3, a percentage reported as inhibition, in the whole organism at one dose (the size of the read-out at that dose, not a potency): 24%
Compound 3: the middle estimate sits 11 percentage points above what was measured; low and high end bracket the measured number.
By their numbers in this assay, from the lowest: compound 1; then compound 3; then compound 2.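

Nitro in place of methoxy on this aromatic carbon gives a number 41 percentage points lower from compound 2 to compound 3 (beyond the scatter) in this assay and so settles the direction that the earlier pair left unknown: of the two groups tried in place of methoxy, neither keeps the read-out of compound 2. Nitro in place of hydroxy gives a number 24 percentage points higher from compound 1 to compound 3 (beyond the scatter) and so shows that the position does not act as a simple on-off switch, since nitro keeps part of the read-out and the three compounds take three separate levels. Nothing on hand says why the three groups fall in this order.

Open, going by these compounds, is where an amine, a chlorine or a longer ether such as ethoxy on this aromatic carbon would fall against methoxy, and whether any group here goes beyond compound 2. Also open, on these data alone, is whether the same order holds at other doses or by other routes, as a read-out at a single dose gives the size of the effect at that dose and not a potency.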